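The source may hold more compounds than are shown below. What is called first, only, known or untested is meant among the compounds shown, and "the series" means these compounds.

Compound 1 `Cc1cc(NC(=O)Cn2nnc(-c3ccccc3)n2)n(C2CCCCC2)n1` is the reference point of this set; in an assay on HEK293 cells for activation of Kir3.1/Kir3.2 (Homo sapiens), read by thallium flux (a higher number here means a larger maximal response, a lower number a smaller maximal response), compound 1 gives 92%. Compound 3 `Cc1cc(NC(=O)Cn2nnc(-c3ccccc3)n2)n(-c2ccccc2)n1` gives 66% in this assay. Compound 2 `CCC(C)n1nc(C)cc1NC(=O)Cn1nnc(-c2ccccc2)n1` reaches only a limit of this assay, > 69%. Among the plain numbers compound 1 stands highest of two, with compound 3 nearest: the step of a number 26 percentage points lower from compound 1 to compound 3 (beyond the scatter) lies beyond the scatter. The step that the limit leaves unreadable from compound 1 to compound 2 cannot be sized because of the limit (the limit of > 69% in this assay, at which 1 of the 3 values shown sits). The step of a number at least 3 percentage points lower from compound 2 to compound 3 (that floor lies within the scatter) has a floor that lies within the scatter.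

Compound 4 `Cc1cc(NC(=O)Cn2nnc(-c3cc(Cl)cc(Cl)c3)n2)n(C2CCCCC2)n1` differs from compound 1 in one place: 3,5-dichlorophenyl in place of phenyl on an aromatic carbon. Within the data shown here, every measured step concerns the group on the aromatic nitrogen; none alters the group on the aromatic carbon of the five-membered ring, so no measured step bears on this change. In this assay no step beyond the scatter in either direction is therefore expected, and the estimate for compound 4 simply carries the value of compound 1 with widened uncertainty. Compound 4 is estimated at 90%, between 65% and 110%, an expected step of a number 2 percentage points lower from compound 1 to compound 4 (within the scatter).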

Compound 4, largest response reached (Emax), in percent of the reference or control that the assay uses: 82%
Estimate against measurement, compound 4: 8 percentage points above; the range from low to high includes it.
By their numbers in this assay, from the lowest: compound 3; then compounds 4 and 1 (each within the scatter of the next).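

Working at the aromatic carbon of the five-membered ring for the first time, the change to 3,5-dichlorophenyl gives a number 10 percentage points lower from compound 1 to compound 4 (within the scatter) in this assay and is the only reading at this position. With cyclohexyl kept on the aromatic nitrogen, this position therefore carries the two chlorine atoms on the phenyl without a step beyond the scatter, whereas the replacement of cyclohexyl by phenyl on the aromatic nitrogen did give such a step. Nothing shown here offers an explanation for the result at this position.

Still open, going by these compounds, is whether the response holds with other groups on this carbon, such as an amine, a carboxylic acid or a saturated cyclohexyl ring in place of the phenyl. Also open, on these data alone, is how 3,5-dichlorophenyl reads with phenyl or sec-butyl on the aromatic nitrogen.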